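The compounds below may be only part of what the source reports. "The series", "measured", "known", "first", "only" and "open" are said of these compounds alone.

Of the compounds shown here, three sharing one core have been measured in a functional assay on SR cells (Homo sapiens) for cytotoxicity, read by sulforhodamine B assay, with a stated time of 48 h, tested at 10 uM; on this read-out lower numbers stand for a stronger effect and higher numbers for a weaker effect at the one concentration tested. Compound 1 `COc1ccc(-c2cc(/C=C/C(=O)c3ccc(OC)c(OC)c3)[nH]n2)cc1` gives -29% in this assay, and compound 3 `COc1ccc(-c2cc(/C=C/C(=O)c3ccc(N)cc3)[nH]n2)cc1OC` gives -13%. Compound 2 `COc1cc(-c2cc(/C=C/C(=O)c3ccc(Cl)c(Cl)c3)[nH]n2)cc(OC)c1OC` gives 8%, the highest of the three numbers and so the weakest effect; its gaps to compound 3 and to compound 1 both lie beyond the usual scatter. Compound 4 `COc1ccc(C(=O)/C=C/c2cc(-c3cc(OC)c(OC)c(OC)c3)n[nH]2)cc1OC` has not been measured yet. It differs from compound 2 in one place: 3,4-dimethoxyphenyl in place of 3,4-dichlorophenyl on a carbonyl carbon. Because compound 1 gives -29% and compound 3 gives -13% in this assay, both well below compound 2, a downward step from compound 2 to compound 4 beyond the scatter is expected, of about a number 28 percentage points lower from compound 2 to compound 4 (beyond the scatter). The estimate for compound 4 in this assay is -20%, with a range from -45% to 5%.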

Compound 4, a percentage reported as activity, at one concentration (the size of the read-out at that concentration, not a potency): 2%
Estimate against measurement, compound 4: 22 percentage points below; low and high end bracket the measured number.
By their numbers in this assay, from the lowest: compound 1; then compound 3; then compounds 4 and 2 (each within the scatter of the next).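

In this assay, going by these compounds alone, 3,4-dimethoxyphenyl in place of 3,4-dichlorophenyl on a carbonyl carbon gives a number 6 percentage points lower from compound 2 to compound 4 (within the scatter), the first comparison here in which only one place changes. At this position, then, the read-out does not separate the two groups, although one has 2 hydrogen-bond acceptors and the other has 0. Nothing available explains this result. Still open, going by these compounds, is whether a carboxylic acid or a nitrile on this phenyl ring would move the read-out beyond the scatter, and whether this same change would give a similar result on another compound.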